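The compounds below may be only part of what the source reports. "The series", "measured", "known", "first", "only" and "open" are said of these compounds alone.

Values measured in a functional assay (strain AB) with Danio rerio as the target, read by microscopy, with a stated time of 1 h; on this read-out lower numbers stand for an effect already at smaller amounts and higher numbers for an effect only at larger amounts of compound:
- compound 1 `CCN1CCc2c(sc(NC(=O)Nc3ccc(Cl)cc3)c2C(N)=O)C1`: 3120 nM
- compound 2 `CC(C)N1CCc2c(sc(NC(=O)Nc3ccc(Cl)cc3)c2C(N)=O)C1`: 1490 nM

Of these two numbers, compound 2 holds the lower one at 1490 nM. Next comes compound 3 `CCCN1CCc2c(sc(NC(=O)Nc3ccc(Cl)cc3)c2C(N)=O)C1`, with propyl in place of isopropyl on an amine nitrogen in a ring. The two structures have the same atoms, joined differently. Going by the values given here, only one measured step bears on this change: a 2.1-fold lower number from compound 1 to compound 2 (0.32 log units; beyond the scatter). That step is modest and was made at the same chain on the nitrogen, where methyl replaced hydrogen on a saturated chain carbon. Among the compounds with values here, no measured compound yet carries propyl, so the data give only a weak guide. A step beyond the scatter is not expected, with a slight lean towards a higher number. The expected step is a 1.3-fold higher number from compound 2 to compound 3 (0.13 log units; within the scatter). For compound 3 the estimated value is 2000 nM, with an expected range of 1000 nM to 4000 nM.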

Compound 3, half-maximal effective concentration: 3500 nM
Compound 3: middle estimate off by 1.8-fold (0.24 log units), on the low side; the range from low to high includes it.
By their numbers in this assay, from the lowest: compound 2; then compounds 1 and 3 (each within the scatter of the next).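

On the amine nitrogen in a ring, the arrangement of the carbons matters and not only their count: in this assay, propyl in place of isopropyl gives a 2.3-fold higher number from compound 2 to compound 3 (0.37 log units; beyond the scatter), with the same heavy atoms on both sides. Methyl in place of hydrogen has different outcomes at two chain carbons: on the carbon bound to the nitrogen it gives a 2.1-fold lower number from compound 1 to compound 2 (0.32 log units; beyond the scatter), whereas two bonds along the chain from the nitrogen it gives a 1.1-fold higher number from compound 1 to compound 3 (0.05 log units; within the scatter), which does not separate the two compounds. Nothing at hand explains the difference between these isomeric chains.

Open, from the compounds shown here alone, is whether a tert-butyl or a cyclopentyl group on the same nitrogen would extend the gain seen with compound 2. Also open, going by these compounds, is whether a longer chain stays level with compound 1 and compound 3.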